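The source may hold more compounds than are shown below. What is called first, only, known or untested is meant among the compounds shown, and "the series" means these compounds.

Working notes on the series.

Compound 1 `Clc1cncc(OC[C@@H]2CCN2)c1` and compound 2 `Cc1cncc(OC[C@@H]2CCN2)c1` share one core and differ only at a substituent on an aromatic carbon. In an assay on brain for binding affinity to Neuronal acetylcholine receptor; alpha4/beta2 (Rattus norvegicus), read by radioligand binding (on this read-out lower numbers stand for stronger inhibition and higher numbers for weaker inhibition), compound 1 gives 0.042 nM, and in this assay compound 2 gives 0.047 nM. Among the compounds with values here, the step of a 1.1-fold higher number from compound 1 to compound 2 (0.05 log units; within the scatter) is within the scatter, so the two numbers cannot be told apart; compound 2 carries the higher of the two figures, with compound 1 its only neighbour.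

Compound 3 `CCc1cncc(OC[C@@H]2CCN2)c1` extends compound 2 by methyl in place of hydrogen on a saturated chain carbon bound to an aromatic carbon, which, taken one bond further out, reads methyl to ethyl. Within the data shown here, no measured pair carries a change at this saturated chain carbon; the single measured step, from chloro to methyl on the aromatic carbon, was within the scatter, and says nothing direct about lengthening the chain. The step of a 1.3-fold higher number from compound 2 to compound 3 (0.11 log units; within the scatter) is therefore expected to stay within the scatter, with no direction claimed. For compound 3 the estimate in this assay is 0.06 nM, between 0.02 nM and 0.2 nM.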

Compound 3, inhibition constant: 0.1 nM
For compound 3 the middle estimate is 1.7-fold (0.22 log units) below the measured one; the measured number falls inside the stated range.
By their numbers in this assay, from the lowest: compounds 1 and 2 (each within the scatter of the next); then compound 3.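

Methyl to ethyl on this aromatic carbon is the first change in the series to reach beyond the scatter in this assay, with a 2.1-fold higher number from compound 2 to compound 3 (0.33 log units; beyond the scatter) as a modest step. Ethyl in place of chloro gives a modest step as well, a 2.4-fold higher number from compound 1 to compound 3 (0.38 log units; beyond the scatter), whereas methyl in place of chloro, a 1.1-fold higher number from compound 1 to compound 2 (0.05 log units; within the scatter), stayed within the scatter, so at this position ethyl separates from the other two substituents while chloro and methyl cannot be told apart. Nothing at hand bears on why the number rises with ethyl.

With a single chain extension, the series cannot show whether the rise continues or levels off with a longer chain such as propyl. It also leaves open where a branched isopropyl or an oxygen-linked methoxy would fall.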